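A few compounds are considered here, and "the series" means these few. Any claim that something is new, unique, unknown or untested is made for them only; others in the source may bear on it.

Measured compounds:
- compound 1, `COc1cc(Cl)cc(-c2nn(-c3cccc(NC(=O)c4ccc(Cl)c(Cl)c4)c3)cc2-c2ccncc2)c1`: 46%
- compound 2, `O=C(Nc1cccc(-n2cc(-c3ccncc3)c(-c3cc(O)cc(Cl)c3)n2)c1)Nc1ccc(Cl)c(Cl)c1`: -15.3%
- compound 3, `COc1cc(Cl)cc(-c2nn(-c3cccc(NC(=O)Nc4ccc(Cl)c(C(F)(F)F)c4)c3)cc2-c2ccncc2)c1`: -29.1%

In a functional assay on RPMI-8226 cells (Homo sapiens) for inhibition, read by sulforhodamine B assay, with a stated time of 48 h, tested at 10 uM (on this read-out higher numbers stand for a weaker effect at the one concentration tested and lower numbers for a stronger effect), compound 3 gives -29.1%, the lowest of the three numbers. Its nearest neighbour is compound 2, which gives -15.3%, and the furthest is compound 1, which gives 46%; both gaps lie beyond the scatter.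

Compound 4, `COc1cc(Cl)cc(-c2nn(-c3cccc(NC(=O)Nc4ccc(Cl)c(Cl)c4)c3)cc2-c2ccncc2)c1`, has not yet been measured in this assay. It differs from compound 3 in one place: chloro in place of trifluoromethyl on an aromatic carbon.

Within the data shown here, only one measured step exists, a number 75.1 percentage points lower from compound 1 to compound 3 (beyond the scatter), and it changes two things at once, the carbonyl-bound group and the aryl, so it does not isolate the chloro-for-trifluoromethyl swap. Among the measured compounds shown here, no measured pair shows that swap alone. Compound 4 carries the same (3,4-dichlorophenyl)amino on a urea as compound 2 does, which in turn has a hydroxyl in place of the methoxy; compound 2 gives -15.3%, and compound 3 with the trifluoromethyl gives -29.1%; the two ureas differ by more than the scatter but not greatly.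

Compound 4 is therefore expected to stay close to compound 3, with a step of about a number 9.1 percentage points higher from compound 3 to compound 4 (within the scatter), upward and small. The value of compound 4 in this assay is estimated at -20%, within a range from -45% to 5%.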

Compound 4, a percentage reported as activity, at one concentration (the size of the read-out at that concentration, not a potency): -4.44%
Beside the measured number, compound 4's estimate is 15.6 percentage points below it; measured number inside the range.
By their numbers in this assay, from the lowest: compound 3; then compound 2; then compound 4; then compound 1.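

Taken alone in this assay, chloro in place of trifluoromethyl on an aromatic carbon, ortho to a chloro group, gives a number 24.7 percentage points higher from compound 3 to compound 4 (beyond the scatter) and so shows that this position responds to the swap even with the urea kept, which the earlier mixed step a number 75.1 percentage points lower from compound 1 to compound 3 (beyond the scatter) could not separate. The change at the carbonyl carbon, (3,4-dichlorophenyl)amino in place of 3,4-dichlorophenyl, gives a number 50.4 percentage points lower from compound 1 to compound 4 (beyond the scatter) and is the largest single change seen here, while methyl in place of hydrogen on the oxygen gives a number 10.9 percentage points higher from compound 2 to compound 4 (beyond the scatter) and shows that the methoxy and hydroxyl forms of the urea also part in this read-out. Nothing measured here explains why any of these changes moves the number.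

The compounds shown leave open how a nitrile, a methyl or a bromo at the same place would compare with chloro and trifluoromethyl. They also leave open whether trifluoromethyl keeps its lower number with the hydroxyl in place of the methoxy, or with the amide in place of the urea.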